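This account rests on a few compounds, and the source may have more. Where it says the series, first, only, none or still open, it means among the compounds named here.

- compound 1 `Cc1ccc(Nc2ccc3c(c2)C(O)(CCC(C)C)C(=O)N3)cc1` gives 12500 nM
- compound 2 `CCCCCCC1(O)C(=O)Nc2ccc(Nc3ccc(C)cc3)cc21` gives 12100 nM

Within the data shown here, in a functional assay on A549 cells (Homo sapiens) for antiproliferative activity, read by MTT assay, with a stated time of 48 h (a lower number here means a stronger inhibitor, a higher number a weaker inhibitor), compound 1 gives 12500 nM and stands level with compound 2, the only other measured compound. Their step (a 1.0-fold lower number from compound 1 to compound 2 (0.01 log units; within the scatter)) changes only the saturated chain and lies within the scatter.

Compound 3 `CC(C)CCC1(O)C(=O)Nc2ccc(Nc3ccc(F)cc3)cc21` keeps the core and the chain of compound 1 and exchanges one group (fluoro in place of methyl on an aromatic carbon): fluoro in place of methyl on an aromatic carbon, so that 4-methylphenyl becomes 4-fluorophenyl. Among the measured compounds shown here, no measured step touches this aromatic ring, and the small step in the chain bears on the exchange only indirectly. Nothing measured points either way, so in this assay no step beyond the scatter is expected. The expected step is a 1.0-fold lower number from compound 1 to compound 3 (0.02 log units; within the scatter) and its uncertainty is wide. The estimated value for compound 3 is 12000 nM (expected range 5000 nM to 28000 nM).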

Compound 3, half-maximal inhibitory concentration: 5700 nM
Compound 3: middle estimate off by 2.1-fold (0.32 log units), on the high side; measured number inside the range.
By their numbers in this assay, from the lowest: compound 3; then compounds 2 and 1 (each within the scatter of the next).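

In this assay, exchanging methyl for fluoro on this aromatic carbon, para to a large group, gives a 2.2-fold lower number from compound 1 to compound 3 (0.34 log units; beyond the scatter), a modest step but the first shown here to lie beyond the scatter. The only earlier step, in the saturated chain, stayed within the scatter, so this aromatic position is the first place shown where changing one group moves the number measurably. No measurement here explains why fluoro gives the lower number.

A single exchange cannot show whether this lower number is particular to fluoro or would also appear with chloro, methoxy or a nitrile on the same carbon. It also leaves open whether the 4-fluorophenyl group would give a similar step when paired with the chain of compound 2.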